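The compounds below may be only part of what the source reports. "The series", "measured", "known", "first", "only" and "open" are said of these compounds alone.

Compound 1 `NCCCOc1ccc([C@H]2CC[C@]3(CC2)OOC2(O3)C3CC4CC(C3)CC2C4)cc1`: < 7 mL.min-1.g-1
Compound 2 `CC(C)(N)CCOc1ccc([C@H]2CC[C@]3(CC2)OOC2(O3)C3CC4CC(C3)CC2C4)cc1`: < 7 mL.min-1.g-1

In an ADME assay on microsomes from liver (Homo sapiens) for metabolic stability, read by LC-MS, tested at 1 uM (on this read-out higher numbers stand for fast clearance and lower numbers for slow clearance), compound 2 gives < 7 mL.min-1.g-1, which is a limit of the assay and not a number. Compound 1 gives < 7 mL.min-1.g-1, also a limit. Together they show only (the limit of < 7 mL.min-1.g-1 in this assay, at which 2 of the 2 values shown sit). Compound 3 `CS(=O)(=O)N1CCN(CCCOc2ccc([C@H]3CC[C@]4(CC3)OOC3(O4)C4CC5CC(C4)CC3C5)cc2)CC1` differs from compound 2 as follows: (4-(methylsulfonyl)piperazin-1-yl)methyl in place of 1-amino-1-methylethyl on a saturated chain carbon, two bonds along the chain from an oxygen on an aromatic ring. Within the data shown here, the only measured step is a step that the two limits leave unreadable from compound 1 to compound 2, so it offers no size to carry over. A modest rise in this assay is expected, with an estimated at least 1.4-fold higher number from compound 2 to compound 3 (0.15 log units; that floor lies within the scatter). The estimate for compound 3 is 10 mL.min-1.g-1, with an expected range of 6 mL.min-1.g-1 to 25 mL.min-1.g-1.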

Compound 3, intrinsic clearance in microsomes: 68 mL.min-1.g-1
Compound 3: the middle estimate sits 6.8-fold (0.83 log units) below what was measured; the whole stated range lies below it.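

In this assay, putting 4-(methylsulfonyl)piperazin-1-yl at the chain end gives an at least 9.7-fold higher number from compound 2 to compound 3 (0.98 log units; beyond the scatter), and the comparison with the unbranched amine gives an at least 9.7-fold higher number from compound 1 to compound 3 (0.98 log units; beyond the scatter). So the group at this chain end can change clearance in human liver microsomes, and by a clear margin. The step between the two amines cannot be read, since each value is only a limit of the assay: the limit of < 7 mL.min-1.g-1 in this assay, at which 2 of the 3 values shown sit.

A plain piperazine without the methylsulfonyl group, or a morpholine, would help show whether the ring or the sulfonyl part goes with the rise.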